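The source may hold more compounds than are shown below. What is called first, only, known or untested is meant among the compounds shown, and "the series" means these compounds.

Compound 1 `Cc1cc(NC(=O)Nc2ccc(C(C)(C)C)cc2)c2ccccc2n1` and compound 2 `Cc1cc(NC(=O)Nc2ccc(F)c(F)c2)c2ccccc2n1` share a common core and differ only in the groups carried on one of their aromatic rings. In an ADME assay on HepG2 cells (Homo sapiens) for cytotoxicity, with a stated time of 72 h (a lower number here means that less compound is needed, a higher number that more compound is needed for the effect), compound 1 gives 17000 nM, and compound 2 gives 21000 nM; these two numbers lie within the usual scatter of each other, so compound 1 does not stand apart from compound 2 on this measure. Compound 3 `COc1ccc(NC(=O)Nc2cc(C)nc3ccccc23)cc1` has not yet been measured in this assay. It differs from compound 1 in one place: methoxy in place of tert-butyl on an aromatic carbon. For the measured compounds named here, no measured pair shows the effect of this particular exchange; the only pair in hand, compound 1 against compound 2, shows that two different groups on that ring give numbers within the scatter. Compound 3 is therefore expected to give a number close to that of compound 1, with a step of a 1.3-fold higher number from compound 1 to compound 3 (0.11 log units; within the scatter) that is expected to remain within the scatter or only slightly beyond it. Compound 3 is estimated at 22000 nM, with a range from 9000 nM to 55000 nM.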

Compound 3, half-maximal effective concentration: > 25000 nM
Compound 3: no number, only a limit; the forecaster's own chance of this, stated with the estimate: 20%; middle value at least 1.1-fold (0.05 log units) away from the limit.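

In this assay compound 3 gives > 25000 nM, which is a limit of the assay and not a number. As far as these compounds go, at this position, on an aromatic carbon para to a large group, methoxy in place of tert-butyl gives an at least 1.4-fold higher number from compound 1 to compound 3 (0.16 log units; that floor lies within the scatter), so this exchange is now seen directly, but only as a floor, and the true size of the step stays unknown. The reading is capped by the top of the measurable range, and the values shown already reach it: the limit of > 25000 nM in this assay, at which 1 of the 3 values shown sits.

From the compounds shown here alone, what remains open is how far the number of compound 3 actually lies from that of compound 1. Also open, going by these compounds, is whether an amine or a carboxylic acid on this carbon would give a number below the limit in this assay.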